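Swapping the Fluorophenyl Arm of Compound 2

The source may report more compounds than this note shows. Statements on the series, on what has been measured and on what is new or still open speak of the compounds shown alone.

Compound 1, `Oc1cccc(-c2cc(-c3ccccc3F)cc(-c3cccc(O)c3)n2)c1`, gives 11200 nM in a functional assay on DU-145 cells (Homo sapiens) for inhibition; on this read-out lower numbers stand for stronger inhibition and higher numbers for weaker inhibition.
Compound 2, `Oc1ccc(-c2cc(-c3ccccc3F)cc(-c3cccc(O)c3)n2)cc1`, gives 3160 nM in this assay.

Among the compounds with values here, only two compounds have been measured so far. Within the data shown here, compound 2 holds the lowest number of the two, and the one measured step, a 3.5-fold lower number from compound 1 to compound 2 (0.55 log units; beyond the scatter), separates it from compound 1. Compound 3, `Oc1ccc(-c2cc(-c3cccc(C(F)(F)F)c3)cc(-c3cccc(O)c3)n2)cc1`, has not yet been measured. It differs from compound 2 in one place: 3-(trifluoromethyl)phenyl in place of 2-fluorophenyl on an aromatic carbon. Among the measured compounds shown here, the single measured step concerns the hydroxyphenyl arms and leaves the fluorophenyl arm untouched, so nothing measured bears directly on the change from compound 2 to compound 3. For the measured compounds named here, with no comparable step to lean on, the expectation for compound 3 is simply that its number stays near that of compound 2 in this assay, with no step beyond the scatter foreseen in either direction; this expected step is a 1.1-fold lower number from compound 2 to compound 3 (0.02 log units; within the scatter). Accordingly, compound 3 is estimated at 3000 nM in this assay, within a wide range from 800 nM to 12000 nM that reflects how little the measured steps say about this change.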

Compound 3, half-maximal inhibitory concentration: 11100 nM
Compound 3: the middle estimate sits 3.7-fold (0.57 log units) below what was measured; the range from low to high includes it.
By their numbers in this assay, from the lowest: compound 2; then compounds 3 and 1 (each within the scatter of the next).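

Until now only the hydroxyphenyl arms had been varied, and this result shows that the arm opposite the ring nitrogen also affects the outcome in this assay: replacing 2-fluorophenyl with 3-(trifluoromethyl)phenyl gives a 3.5-fold higher number from compound 2 to compound 3 (0.55 log units; beyond the scatter) and so weaker inhibition. The swap changes two things at once, since the substituent on this phenyl ring goes from a single fluorine to trifluoromethyl and its place on that ring changes too, as the two group names show, so this one step cannot tell which of the two matters. Nothing available explains why the number rises.

Going by these compounds, it remains open whether 3-fluorophenyl or 2-(trifluoromethyl)phenyl at this position would give a number closer to that of compound 2 or compound 3, which would begin to separate the two changes. On these data alone, it is equally open how a plain phenyl ring, or a phenyl ring carrying an amine or a carboxylic acid, would behave here.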